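The source may report more compounds than this note shows. Statements on the series, on what has been measured and on what is new or still open speak of the compounds shown alone.

In an ADME assay on HaCaT cells (Homo sapiens) for inhibition, read by sulforhodamine B assay, with a stated time of 48 h (a higher number here means a weaker inhibitor of growth, a lower number a stronger inhibitor of growth), compound 3 `CC(C)(C)NCc1c(C(=O)O)nn(-c2ccccc2)c1-c1ccccc1` gives only a limit, > 716000 nM. Compound 2 `CC(C)(C)NCc1c(C(=O)O)nn(-c2ccccc2)c1-c1ccc(Cl)cc1` also gives only a limit, > 652000 nM. Compound 1 `CCOC(=O)c1nn(-c2ccccc2)c(-c2ccc(OC)cc2)c1CNC(C)(C)C` is the only one of the three with numbers, 68300 nM; 19200 nM (2 entries), and these two entries do not agree closely with each other.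

The next compound, compound 4 `COc1ccc(-c2c(CNC(C)(C)C)c(C(=O)O)nn2-c2ccccc2)cc1`, differs from compound 3 by methoxy in place of hydrogen on an aromatic carbon, the change from phenyl to 4-methoxyphenyl: methoxy in place of hydrogen on an aromatic carbon.

Going by the values given here, only one measured step bears on this position, a step that the two limits leave unreadable from compound 2 to compound 3, and it gives no size to carry over. Among the compounds with values here, no measured step shows what methoxy does here. The expectation therefore rests on compound 3 and its limit, > 716000 nM, and no step beyond the scatter is expected in this assay, in either direction. Another limit is the likeliest report.

The expected step is an at least 1.0-fold lower number from compound 3 to compound 4 (0.03 log units; that floor lies within the scatter). For compound 4 the estimated value is 660000 nM, with an expected range from 250000 nM to 900000 nM.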

Compound 4, concentration for 50% growth inhibition: > 659000 nM
Compound 4 gave a limit, no number (the forecaster's own chance of this, stated with the estimate: 85%); the middle value lies beyond the limit too.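

Going by these compounds alone, compound 2, compound 3 and compound 4 all give only limits in this assay, so no step among them can be read. What the compounds shown leave open is whether chloro, methoxy or hydrogen on the aromatic carbon changes growth inhibition at all.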